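Swapping the Nitrophenyl Amide for a Trifluoromethylphenyl Amide

A few compounds are considered here, and "the series" means these few. Any claim that something is new, unique, unknown or untested is made for them only; others in the source may bear on it.

Measured so far in a functional assay on MDA-MB-231 cells (Homo sapiens) for inhibition, read by MTT assay, with a stated time of 72 h; on this read-out lower numbers stand for stronger inhibition and higher numbers for weaker inhibition:
- compound 1 `O=C(CSc1nc(Nc2ccccc2)c2ccccc2n1)Nc1cccc(Cl)c1` gives 16500 nM
- compound 2 `O=C(CSc1nc(Nc2ccccc2)c2ccccc2n1)Nc1cccc([N+](=O)[O-])c1` gives 33000 nM
- compound 3 `C=CC(=O)Nc1cccc(NC(=O)CSc2nc(Nc3ccccc3)c3ccccc3n2)c1` gives 10200 nM

All three share one core and differ only in the group on the amide nitrogen. Among the measured compounds shown here, compound 2 stands at the highest number of the three, meaning the weakest inhibition; the step of a 2.0-fold higher number from compound 1 to compound 2 (0.30 log units; within the scatter) lies within the scatter, while the step of a 3.2-fold lower number from compound 2 to compound 3 (0.51 log units; beyond the scatter) is beyond it, so compound 3 is the only one clearly separated from compound 2.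

Compound 4 `O=C(CSc1nc(Nc2ccccc2)c2ccccc2n1)Nc1ccc(C(F)(F)F)cc1` is not yet measured. It differs from compound 2 in one place: 4-(trifluoromethyl)phenyl in place of 3-nitrophenyl on an amide-type nitrogen.

For the measured compounds named here, two measured steps bear on this change, since both alter the same group on the amide nitrogen. Replacing nitro by chloro gave a 2.0-fold higher number from compound 1 to compound 2 (0.30 log units; within the scatter) read in reverse, and replacing nitro by the acrylamide gave a 3.2-fold lower number from compound 2 to compound 3 (0.51 log units; beyond the scatter). Both moves away from the nitrophenyl lowered the number, modestly or within the scatter. A similar outcome is expected here: a small drop, a 1.8-fold lower number from compound 2 to compound 4 (0.26 log units; within the scatter), probably not far beyond the scatter. Compound 4 is therefore estimated at 18000 nM, with a plausible range from 7000 nM to 45000 nM.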

Compound 4, half-maximal inhibitory concentration: 11100 nM
Compound 4: the middle estimate sits 1.6-fold (0.21 log units) above what was measured; low and high end bracket the measured number.
By their numbers in this assay, from the lowest: compounds 3, 4, 1 and 2 (each within the scatter of the next, the first and the last beyond it).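

In this assay, 4-(trifluoromethyl)phenyl on the amide nitrogen gives a 3.0-fold lower number from compound 2 to compound 4 (0.47 log units; beyond the scatter), which makes it the second replacement of 3-nitrophenyl, after the acrylamide-bearing group of compound 3, to stand clearly apart from compound 2. The other two comparisons, a 1.1-fold higher number from compound 3 to compound 4 (0.04 log units; within the scatter) and a 1.5-fold lower number from compound 1 to compound 4 (0.17 log units; within the scatter), stay within the scatter, so compound 4 cannot be told apart from compound 3 or compound 1, and among these compounds the (vinylcarbonyl)amino group is not needed to reach the level of compound 3. Nothing available here explains why these groups give the numbers they do.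

3-Nitrophenyl and 4-(trifluoromethyl)phenyl differ both in the substituent and in where it sits on the ring, and the compounds shown do not separate these two changes, so the step from compound 2 cannot be credited to either one alone. On these data alone, it also remains open how this position would respond to an amine or a carboxylic acid on the same ring, or to a longer chain between the amide nitrogen and the ring.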